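Amino for Hydrogen on the Purine-Type Core of Compound 2

The compounds below may be only part of what the source reports. "The series", "measured", "known", "first", "only" and "open" are said of these compounds alone.

Measured so far:
compound 1, `ClCc1ccc(Cn2cnc3c(Cl)ncnc32)cc1`, > 100000 nM
compound 2, `ClCc1cccc(Cn2cnc3c(Cl)ncnc32)c1`, 75900 nM
compound 3, `ClCc1cccc(Cn2cnc3nc(Cl)nc(Cl)c32)c1`, 5240 nM

In a functional assay on K562 cells (Homo sapiens) for cytotoxicity, read by sulforhodamine B assay, with a stated time of 48 h (a lower number here means that less compound is tolerated, a higher number that more compound is tolerated), compound 1 reaches only a limit, > 100000 nM, which is a limit of the measurement and not a number (the limit of > 100000 nM in this assay, at which 1 of the 3 values shown sits). Compound 2 gives the higher of the two numbers in this assay, at 75900 nM. Going by the values given here, compound 3, the only other numbered value, gives 5240 nM in this assay, a lower figure that lies beyond the scatter.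

The next compound, compound 4, `Nc1nc(Cl)c2ncn(Cc3cccc(CCl)c3)c2n1`, is not yet measured. Compared with compound 2 the change is amino in place of hydrogen on an aromatic carbon. Among the compounds with values here, no measured pair shows this step, so its size is open. The account expects compound 4 to sit somewhat lower than compound 2 in this assay, a step of a 1.9-fold lower number from compound 2 to compound 4 (0.28 log units; within the scatter), though a result within the scatter would not surprise. The estimate for compound 4 is 40000 nM, with a range from 8000 nM to 150000 nM.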

Compound 4, concentration lethal to 50% of the cells: > 100000 nM
Compound 4 gave a limit, no number; the forecaster's own chance of this, stated with the estimate: 20%; middle value at least 2.5-fold (0.39 log units) away from the limit.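

In this assay compound 4 gives > 100000 nM, which is a limit of the measurement and not a number: the limit of > 100000 nM in this assay, at which 2 of the 4 values shown sit. Amino in place of hydrogen on an aromatic carbon, between two ring nitrogen atoms, gives an at least 1.3-fold higher number from compound 2 to compound 4 (0.11 log units; that floor lies within the scatter), and this floor alone does not separate the two compounds. The earlier compounds shown here held no step at this position, and this first one shows no lower number with amino there, only a result that may lie anywhere from the floor upward.

On these data alone, how far compound 4 lies past its limit stays open, so the full size of the step cannot be read. Also open, as far as these compounds go, is whether a hydroxyl, a methoxy or a dimethylamino group on this same carbon would give a number in this assay.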